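The compounds below may be only part of what the source reports. "The series", "measured", "known", "first", "only" and "open" are said of these compounds alone.

Measured so far:
- Compound 1, `COc1cc(O)c(C(=O)/C=C/c2ccc(F)cc2)c(OC)c1`: "not active" (no number reported)
- Compound 2, `COc1cc(OC)c(C(=O)/C=C/c2ccccc2SC)c(OC)c1`: 0%
- Compound 3, `COc1cc(O)c(C(=O)/C=C/c2ccccc2OC)c(OC)c1`: 29%

In a functional assay on HaCaT cells (Homo sapiens), read by fluorescence and BrdU incorporation, with a stated time of 48 h, tested at 25 uM (a lower number here means a stronger effect, a higher number a weaker effect of the compound at the concentration tested), compound 3 gives 29%, the higher of the two numbers reported; compound 2, at 0%, lies a good way under it, a gap beyond the usual scatter, while compound 1 is simply recorded as inactive without a number. Compound 4, `COc1cc(O)c(C(=O)/C=C/c2ccccc2SC)c(OC)c1`, keeps the shared core and the hydroxy group of compound 3 but changes the substituent on the other ring: methylsulfanyl in place of methoxy on an aromatic carbon. Within the data shown here, no measured pair with exactly this change exists among the three compounds, so the size of the step cannot be read off directly. Among the measured compounds shown here, the only hint comes from compound 2, which carries the same methylsulfanyl group and gives 0% in this assay. On that basis the number for compound 4 is expected to come down from that of compound 3, a step of a number 14 percentage points lower from compound 3 to compound 4 (beyond the scatter), though with wide uncertainty. The value of compound 4 in this assay is estimated at 15%, between 0% and 35%.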

Compound 4, a percentage reported as activity, at one concentration (the size of the read-out at that concentration, not a potency): 30%
For compound 4 the middle estimate is 15 percentage points below the measured one; measured number inside the range.
By their numbers in this assay, from the lowest: compound 2; then compounds 3 and 4 (each within the scatter of the next).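

In this assay, methylsulfanyl in place of methoxy on an aromatic carbon, ortho to a large group, gives a step (a number 1 percentage points higher from compound 3 to compound 4 (within the scatter)), so with the hydroxy group kept, these two groups cannot be told apart at this position. The methylsulfanyl group alone therefore does not go with the strong effect of compound 2: with that group held constant, hydrogen in place of methyl on an oxygen on the aromatic ring gives a clear step (a number 30 percentage points higher from compound 2 to compound 4 (beyond the scatter)), which points to that oxygen as the place that matters in this pair. Nothing available here explains why either step has the size it does.

Still open, on these data alone, is whether the same change on the oxygen would move the number as far with methoxy on the other ring. It is also unknown whether a quite different group at this position, such as an amine or a carboxylic acid, would behave like methoxy and methylsulfanyl.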